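This account rests on a few compounds, and the source may have more. Where it says the series, first, only, none or still open, it means among the compounds named here.

Working notes on the series. Compound 1 `CCCSc1nc(N)c2nc(O)n(Cc3ccccc3)c2n1` and compound 2 `CCCCc1nc(N)c2nc(O)n(Cc3ccccc3)c2n1` share one core, while compound 3 `COc1nc2c(N)ncnc2n1Cc1ccccc1` is built on a different core. In a functional assay (spleen, spleen) for activation, with Mus musculus as the target (a lower number here means that less compound is needed, a higher number that more compound is needed for the effect), compound 1 gives 0.01 uM. In this assay compound 2 gives 0.03 uM. Among the compounds with values here, the only step between measured neighbours, a 3.0-fold higher number from compound 1 to compound 2 (0.48 log units; beyond the scatter), is the exchange of butyl in place of propylsulfanyl on an aromatic carbon, and it sits on the core of compound 1 and compound 2, not on that of compound 3.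

In this assay compound 3 gives > 10 uM, which is a limit of the assay and not a number. This is the position described by the limit of > 10 uM in this assay, at which 1 of the 3 values shown sits. Compound 3 therefore stands apart from compound 1 and compound 2, which both return numbers well inside the measured range.

The next compound is compound 4 `Cc1nc2c(N)ncnc2n1Cc1ccccc1`. The change from compound 3 is methyl in place of methoxy on an aromatic carbon. Within the data shown here, no measured step touches this core or this exchange, so the step from compound 1 to compound 2 gives no guide to size or direction here, and the starting point is itself a limit. The expectation for compound 4 is that the value stays near that limit, an estimated step that the limit leaves unreadable from compound 3 to compound 4. For compound 4 the estimate is 20 uM, with a range from 5 uM to 100 uM.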

Compound 4, minimum effective concentration: > 10 uM
Compound 4 ended at the assay's limit; the forecaster's own chance of this, stated with the estimate: 70%; the middle value lies beyond the limit too.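

Compound 3 and compound 4 both sit at a limit of this assay and not at a number, so no step can be read between them: the limit of > 10 uM in this assay, at which 2 of the 4 values shown sit. The compounds shown leave open whether methyl in place of methoxy on an aromatic carbon changes the response on this core at all.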